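Sulfonyl substituent change and mouse microsomal clearance

A few compounds are considered here, and "the series" means these few. Any claim that something is new, unique, unknown or untested is made for them only; others in the source may bear on it.

Compound 2, `O=C(Nc1cccc(S(=O)(=O)N2CCCC2)c1)c1cccnc1N1CCC2(CC1)CC2`: > 399 mL.min-1.g-1
Compound 1, `O=C(Nc1cccc(S(=O)(=O)C2CCCC2)n1)c1ccc(NCCO)cc1N1CCC2(CC1)CC2`: > 399 mL.min-1.g-1

Compound 2 gives only a limit in an ADME assay on microsomes from liver (Mus musculus) for metabolic stability, read by LC-MS, with a stated time of 40 min, tested at 0.5 uM (a lower number here means slower removal, a higher number faster removal of the compound), reported as > 399 mL.min-1.g-1. Compound 1 likewise sits at a limit in this assay, reported as > 399 mL.min-1.g-1. Both measured values therefore sit at the limit of > 399 mL.min-1.g-1 in this assay, at which 2 of the 2 values shown sit, so compound 2 stands at the upper edge of what this assay can report, and no ordering of compounds 1 and 2 can be drawn from these two readings.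

Compound 3 `CC(C)(CO)S(=O)(=O)c1cccc(NC(=O)c2cccnc2N2CCC3(CC2)CC3)c1` has not yet been measured. It differs from compound 2 in a single place: 1-(hydroxymethyl)-1-methylethyl in place of pyrrolidin-1-yl on a sulfonyl sulfur. Going by the values given here, no measured step between compounds is available to guide the expectation, and the two known values offer only limits. The expected step in this assay is an at least 1.3-fold lower number from compound 2 to compound 3 (0.12 log units; that floor lies within the scatter), a move toward slower removal that is expected to be small enough that the value may remain at or near the limit. Compound 3 is accordingly estimated at 300 mL.min-1.g-1, with a range from 120 mL.min-1.g-1 to 399 mL.min-1.g-1.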

Compound 3, intrinsic clearance in microsomes: > 399 mL.min-1.g-1
Compound 3 was reported as a limit; the forecaster's own chance of this, stated with the estimate: 55%; middle value at least 1.3-fold (0.12 log units) from the limit.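

Compound 3 gives > 399 mL.min-1.g-1 in this assay, which is a limit. Going by these compounds alone, compound 2 sits at the same limit, so no step between compound 2 and compound 3 can be read: the limit of > 399 mL.min-1.g-1 in this assay, at which 3 of the 3 values shown sit. The compounds shown leave open whether 1-(hydroxymethyl)-1-methylethyl in place of pyrrolidin-1-yl on a sulfonyl sulfur changes intrinsic clearance at all.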